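Replacing a cyclobutyl with a 3,4-dichlorophenyl

The compounds below may be only part of what the source reports. "The series", "measured", "known", "first", "only" and "open" are said of these compounds alone.

Measured so far in an assay on cells for displacement of a labelled ligand from corticotropin-releasing factor receptor 1 (Homo sapiens), with a stated time of 100 min; on this read-out lower numbers stand for stronger inhibition and higher numbers for weaker inhibition:
- compound 1, `CCN(Cc1c(C(F)(F)F)nc2n(-c3c(C)cc(C)cc3C)c(Cl)cn12)CC1CC1`: 9 nM
- compound 2, `C=CCN(CCC)Cc1c(C(F)(F)F)nc2n(-c3c(C)cc(C)cc3C)c(Cl)cn12`: 4.5 nM
- compound 3, `CCN(Cc1c(C(F)(F)F)nc2n(-c3c(C)cc(C)cc3C)c(Cl)cn12)CC1CCC1`: 16 nM

Compound 3 gives the highest of the three numbers in this assay. Its nearest neighbour is compound 1, and that step, a 1.8-fold higher number from compound 1 to compound 3 (0.25 log units; within the scatter), lies within the scatter; the step of a 3.6-fold higher number from compound 2 to compound 3 (0.55 log units; beyond the scatter) is the only one beyond it, and it is modest.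

Compound 4, `CCN(Cc1ccc(Cl)c(Cl)c1)Cc1c(C(F)(F)F)nc2n(-c3c(C)cc(C)cc3C)c(Cl)cn12`, differs from compound 3 in one place: 3,4-dichlorophenyl in place of cyclobutyl on a saturated chain carbon bound to an amine nitrogen. Both measured steps that change the amine substituent bear on this, and both were small: a 2.0-fold lower number from compound 1 to compound 2 (0.30 log units; within the scatter) and a 3.6-fold higher number from compound 2 to compound 3 (0.55 log units; beyond the scatter). None of them, however, introduces an aromatic ring at this position, so the data give no direct guide for this exchange. The amine substituent has so far shifted this assay by modest amounts only, so compound 4 is expected to stay in the same region, with a wide range to allow for the untested change, an expected step of a 1.6-fold higher number from compound 3 to compound 4 (0.19 log units; within the scatter). The estimate for compound 4 in this assay is therefore 25 nM, with a range from 6 nM to 100 nM.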

Compound 4, inhibition constant: 580 nM
Compound 4: the middle estimate sits 23-fold (1.37 log units) below what was measured, and the stated range ends below it.
By their numbers in this assay, from the lowest: compounds 2, 1 and 3 (each within the scatter of the next, the first and the last beyond it); then compound 4.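

In this assay the step of a 36-fold higher number from compound 3 to compound 4 (1.56 log units; beyond the scatter) is large, and so is the step of a 64-fold higher number from compound 1 to compound 4 (1.81 log units; beyond the scatter), with 3,4-dichlorophenyl in place of cyclobutyl and of cyclopropyl respectively on the same saturated chain carbon bound to an amine nitrogen. The earlier exchanges at this amine moved the number by modest amounts at most, whereas this one shows that the position does not accept every substituent and that a small carbocycle cannot be swapped for a dichlorinated aromatic ring without a heavy loss of inhibition. No measurement given here accounts for this loss.

The compounds shown leave open whether the loss follows the aromatic ring or its two chlorines, a question that plain benzyl or 4-chlorobenzyl at this place would address. Going by these compounds, whether a larger saturated ring such as cyclohexylmethyl is accepted also remains open.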